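Notes on the amine nitrogen substituent in this series

The source may hold more compounds than are shown below. What is called first, only, known or untested is meant among the compounds shown, and "the series" means these compounds.

Measured so far in a functional assay on HEL cells (Homo sapiens); on this read-out higher numbers stand for lower toxicity in this test and lower numbers for higher toxicity in this test
- compound 1 `COC(=O)CC(=O)NC1=CS(=O)(=O)O[C@@]12[C@@H](CO[Si](C)(C)C(C)(C)C)O[C@@H](n1cc(C)c(=O)n(C)c1=O)[C@@H]2O[Si](C)(C)C(C)(C)C` gives 29000 nM
- compound 2 `Cc1cn([C@@H]2O[C@H](CO[Si](C)(C)C(C)(C)C)[C@@]3(OS(=O)(=O)C=C3NCC(=O)OCc3ccccc3)[C@H]2O[Si](C)(C)C(C)(C)C)c(=O)n(C)c1=O` gives > 200000 nM (a limit, not a number)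

Compound 2 has only a limit in this assay and so has no exact place on the scale. This is the limit of > 200000 nM in this assay, at which 1 of the 2 values shown sits, and nothing more can be read from it.

Compound 3 `Cc1cn([C@@H]2O[C@H](CO[Si](C)(C)C(C)(C)C)[C@@]3(OS(=O)(=O)C=C3NC(=O)NC(=O)c3ccccc3)[C@H]2O[Si](C)(C)C(C)(C)C)c(=O)n(C)c1=O` carries benzoylcarbamoyl in place of (benzyloxycarbonyl)methyl on an amine nitrogen and keeps the shared core.

Among the compounds with values here, one measured step bears on this change, an at least 6.8-fold higher number from compound 1 to compound 2 (0.83 log units; beyond the scatter) and it lies beyond the scatter. Going by these compounds, its true size remains open on the side of compound 2. Like ((methoxycarbonyl)methyl)carbonyl in compound 1 at 29000 nM the entering benzoylcarbamoyl joins the amine nitrogen through a carbonyl, so a return toward that value is expected. A lower number is therefore expected, and the estimated change an at least 2.8-fold lower number from compound 2 to compound 3 (0.45 log units; beyond the scatter) is read in that direction. Compound 3 is expected at 70000 nM within an estimated range of 20000 nM to 200000 nM in this assay once measured.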

Compound 3, half-maximal cytotoxic concentration: >= 200000 nM
Compound 3 was reported as a limit; the forecaster's own chance of this, stated with the estimate: 35%; middle value at least 2.8-fold (0.45 log units) away from the limit.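

In this assay compound 3 gives >= 200000 nM, which is a limit and not a number: the limit of >= 200000 nM in this assay, at which 1 of the 3 values shown sits.

A carbonyl on the amine nitrogen is thus not sufficient for the lower number seen in this pair, as benzamido in place of (methoxycarbonyl)methyl on a carbonyl carbon gives an at least 6.8-fold higher number from compound 1 to compound 3 (0.83 log units; beyond the scatter). The steps between the two limit compounds cannot be read, and compound 1 is now the only one of the three with an exact value and the only one whose substituent on the amine nitrogen has no six-membered aromatic ring of carbon only, an association that rests on these three compounds alone.

The compounds shown do not separate the aromatic ring from the rest of each substituent, and an acetyl group on the amine nitrogen would bear on that point. Going by these compounds, how far compound 2 and compound 3 lie beyond their limits stays open, as does the effect of a carboxylic acid in place of the methyl ester of compound 1.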